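The compounds below may be only part of what the source reports. "The series", "measured", "known", "first", "only" and "open" are said of these compounds alone.

Compound 1, `COc1ccc(-c2ccnc(C(=O)Nc3ccc(Oc4ccnc5cc(OCCCN6CCN(C)CC6)c(OC)cc45)c(F)c3)c2)cc1`, in a functional assay on HT-29 cells (Homo sapiens) for cytotoxicity, read by MTT assay, with a stated time of 72 h; a lower number here means a stronger inhibitor, a higher number a weaker inhibitor: 390 nM
Compound 2, `COc1cc2c(Oc3ccc(NC(=O)c4cc(-c5ccccc5)ccn4)cc3F)ccnc2cc1OCCCN1CCCCC1`, in this assay: 270 nM
Compound 3, `COc1cc2c(Oc3ccc(NC(=O)c4nccc(-c5ccccc5)n4)cc3F)ccnc2cc1OCCCN1CCCCC1`, in this assay: 260 nM

Compound 3 carries the lowest number of the three, but the gaps to compound 2 and compound 1 both lie within the scatter, so no ranking among them can be read from these numbers.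

Compound 4, `COc1cc2c(Oc3ccc(NC(=O)c4nccc(-c5ccc(F)cc5F)n4)cc3F)ccnc2cc1OCCCN1CCCCC1`, has not been measured. It differs from compound 3 in one place: 2,4-difluorophenyl in place of phenyl on an aromatic carbon.

Going by the values given here, only one single-point step is available, a 1.0-fold lower number from compound 2 to compound 3 (0.02 log units; within the scatter), and it concerns the ring that bears the phenyl rather than the phenyl itself; it was within the scatter. Compound 1 and compound 3 differ in two places, and their values are also within the scatter of each other. Among the compounds with values here, no measured step touches the phenyl, so there is nothing to argue for a move beyond the scatter in either direction in this assay.

Compound 4 is therefore expected near compound 3, at 230 nM, with a range of 100 nM to 520 nM; the expected step is a 1.1-fold lower number from compound 3 to compound 4 (0.05 log units; within the scatter).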

Compound 4, half-maximal inhibitory concentration: 400 nM
For compound 4 the middle estimate is 1.7-fold (0.24 log units) below the measured one; the measured number falls inside the stated range.
By their numbers in this assay, from the lowest: compounds 3, 2, 1 and 4 (each within the scatter of the next).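

The earlier step altered only the ring bearing the phenyl, whereas this one alters the phenyl itself, on an aromatic carbon of a six-membered aromatic ring with 2 nitrogen. In this assay, 2,4-difluorophenyl in place of phenyl gives a 1.5-fold higher number from compound 3 to compound 4 (0.19 log units; within the scatter), so the two values stand within the scatter of each other and this position accepts the two added fluorine atoms with no readable effect on the number. No measured evidence bears on the reading of this result.

Open, as far as these compounds go, is whether a single fluorine on the phenyl, as in 4-fluorophenyl, or a larger or charged substituent, such as a dimethylamino group or a carboxylic acid, would move the number beyond the scatter. Also open, from the compounds shown here alone, is whether any group at this position can separate these compounds in this cell assay at all.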